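This account rests on a few compounds, and the source may have more. Where it says the series, first, only, none or still open, it means among the compounds named here.

In a functional assay on SMMC-7721 cells (Homo sapiens) for inhibition, read by MTT assay, with a stated time of 48 h (on this read-out higher numbers stand for weaker inhibition and lower numbers for stronger inhibition), compound 1 `Cc1ccc(NC(=O)Nc2cccc(-c3cccc4[nH]nc(N)c34)c2)cc1` gives 4450 nM, compound 2 `Cc1ccc(NC(=O)Nc2cccc(-c3cccc4[nH]nc(N)c34)c2)cc1Cl` gives 510 nM and compound 3 `Nc1n[nH]c2cccc(-c3cccc(NC(=O)Nc4ccc(F)c(F)c4)c3)c12` gives 5880 nM. The number for compound 3 stands at the weak end of this small set, with a 1.3-fold higher number from compound 1 to compound 3 (0.12 log units; within the scatter) and a 12-fold higher number from compound 2 to compound 3 (1.06 log units; beyond the scatter). Compound 4 `Nc1n[nH]c2cccc(-c3cccc(NC(=O)Nc4ccc(Cl)cc4Cl)c3)c12` carries 2,4-dichlorophenyl in place of 3,4-difluorophenyl on an amide-type nitrogen. Within the data shown here, the closest evidence is chloro in place of hydrogen on an aromatic carbon, with an 8.7-fold lower number from compound 1 to compound 2 (0.94 log units; beyond the scatter), a modest step, but no measured compound carries 2,4-dichlorophenyl. A smaller move towards stronger inhibition is therefore expected in this assay, and the estimated change is a 2.9-fold lower number from compound 3 to compound 4 (0.47 log units; beyond the scatter). The estimate for compound 4 is 2000 nM, with an expected range from 600 nM to 6500 nM.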

Compound 4, half-maximal inhibitory concentration: 1900 nM
The estimate for compound 4 lay 1.1-fold (0.02 log units) above the measured number; low and high end bracket the measured number.
By their numbers in this assay, from the lowest: compound 2; then compound 4; then compounds 1 and 3 (each within the scatter of the next).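

In this assay, exchanging one dihalogenated phenyl group for another on the amide-type nitrogen moves the number beyond the scatter, a 3.1-fold lower number from compound 3 to compound 4 (0.49 log units; beyond the scatter), so the halogens' identity or placement matters here, not only the presence of chloro. The 2,4-dichlorophenyl group loses ground to 3-chloro-4-methylphenyl, a 3.7-fold higher number from compound 2 to compound 4 (0.57 log units; beyond the scatter), but gains on 4-methylphenyl, a 2.3-fold lower number from compound 1 to compound 4 (0.37 log units; beyond the scatter). No measurement at hand explains these differences. The compounds shown leave open whether both chloro groups are needed, and how a phenyl ring carrying a single chloro, methoxy or trifluoromethyl group would read here.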